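Removing a Methyl from the Methoxy Group of Compound 1

The compounds below may be only part of what the source reports. "The series", "measured", "known", "first", "only" and "open" are said of these compounds alone.

Among the measured compounds shown here, in a functional assay on UACC-62 cells (Homo sapiens) for antiproliferative activity, read by sulforhodamine B assay, with a stated time of 48 h (on this read-out lower numbers stand for stronger inhibition and higher numbers for weaker inhibition), compound 1 `COc1cc(-c2nn(-c3ccc(NC(=O)Nc4ccc(Cl)c(C(F)(F)F)c4)cc3)cc2-c2ccncc2)ccc1Cl` gives 1770 nM, the lowest of the two numbers measured so far. For the measured compounds named here, its neighbour compound 2 `COc1cc(-c2nn(-c3ccc(NC(=O)c4cc(Cl)cc(Cl)c4)cc3)cc2-c2ccncc2)ccc1Cl` gives 4580 nM, and the only measured step, a 2.6-fold higher number from compound 1 to compound 2 (0.41 log units; beyond the scatter), alters the group on the carbonyl carbon rather than the methoxy. Compound 3 `O=C(Nc1ccc(-n2cc(-c3ccncc3)c(-c3ccc(Cl)c(O)c3)n2)cc1)Nc1ccc(Cl)c(C(F)(F)F)c1` differs from compound 1 elsewhere: hydrogen in place of methyl on an oxygen on an aromatic ring. Going by the values given here, no measured step touches that change, so its size cannot be read from the data; a shift within the scatter in either direction is expected. Compound 3 is therefore estimated at 1500 nM, between 500 nM and 4500 nM. That estimate means an expected step of a 1.2-fold lower number from compound 1 to compound 3 (0.07 log units; within the scatter).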

Compound 3, half-maximal inhibitory concentration: 1700 nM
For compound 3 the middle estimate is 1.1-fold (0.05 log units) below the measured one; measured number inside the range.
By their numbers in this assay, from the lowest: compounds 3 and 1 (each within the scatter of the next); then compound 2.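

Replacing methoxy with hydroxy, as in the step from 4-chloro-3-methoxyphenyl to 4-chloro-3-hydroxyphenyl, leaves the two compounds indistinguishable in this assay (a 1.0-fold lower number from compound 1 to compound 3 (0.02 log units; within the scatter)). Among the compounds shown here, this is the first reading at this oxygen, and it shows that the methyl can be lost there without a difference the assay can resolve. No available evidence bears on this result. Still open, going by these compounds, is whether a longer chain on this oxygen, such as ethoxy, would also stay within the scatter. On these data alone, an amine in place of the hydroxy remains equally open.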